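Sulfonamide series on DLD-1 cells: from compound 2 toward compound 4

A few compounds are considered here, and "the series" means these few. Any claim that something is new, unique, unknown or untested is made for them only; others in the source may bear on it.

Measured so far:
compound 1 `Cc1ccc(-c2ccccc2S(=O)(=O)N2CCC(N3CCC(C)CC3)CC2)cc1` — 366 nM
compound 2 `CC1CCN(C2CCN(S(=O)(=O)c3ccc(OCc4ccccc4)cc3)CC2)CC1` — 385 nM
compound 3 `Cc1nc(Cl)sc1S(=O)(=O)N1CCC(N2CCC(C)CC2)CC1` — 1.6 nM

In a functional assay on DLD-1 cells (Homo sapiens) for antiproliferative activity, read by CellTiter-Glo, with a stated time of 72 h (a lower number here means a stronger inhibitor, a higher number a weaker inhibitor), compound 2 gives 385 nM, the highest of the three numbers. Compound 1, with 366 nM, sits within the scatter of compound 2, so the two cannot be ordered. Among the compounds with values here, compound 3, with 1.6 nM, lies far beyond the scatter of both and is the only compound whose steps to all others are beyond the scatter.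

Compound 4 `COc1ccc(-c2ccc(S(=O)(=O)N3CCC(N4CCC(C)CC4)CC3)cc2)cc1` is not yet measured in this assay. It differs from compound 2 only in how the same atoms are joined: 4-methoxyphenyl in place of benzyloxy on an aromatic carbon. The new group sits on an aromatic carbon of a six-membered aromatic ring of carbon only, para to a large group.

Within the data shown here, no step between two measured compounds mirrors this change, so the direction of the step is open. Compound 1 also carries an aryl group directly on the sulfonyl-bearing ring and gives 366 nM, which sits within the scatter of compound 2. The expectation is therefore a step of a 1.5-fold lower number from compound 2 to compound 4 (0.19 log units; within the scatter) that does not clearly leave the scatter. Compound 4 is estimated at 250 nM, with a range from 60 nM to 1000 nM.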

Compound 4, half-maximal inhibitory concentration: 263 nM
Beside the measured number, compound 4's estimate is 1.1-fold (0.02 log units) below it; the range from low to high includes it.
By their numbers in this assay, from the lowest: compound 3; then compounds 4, 1 and 2 (each within the scatter of the next).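

In this assay, within the data shown here, the exchange of benzyloxy for 4-methoxyphenyl gives a 1.5-fold lower number from compound 2 to compound 4 (0.17 log units; within the scatter) as the first step between two compounds that differ in one place. The two groups match in heavy atoms, aromatic ring and hydrogen-bond acceptor count, so this pair isolates how the same atoms are joined, and at this place, on an aromatic carbon para to a large group, that rejoining does not carry the number beyond the scatter. No supporting measurement bears on this result, so the step stands as an observation on a single pair without an explanation attached.

Still open, from the compounds shown here alone, is whether any replacement at this aromatic carbon can move the number beyond the scatter, which a carboxylic acid, a primary amine or a morpholine in place of the 4-methoxyphenyl group would test. Also open, going by these compounds, is whether the methoxy group of the 4-methoxyphenyl group contributes to the number at all, which the unsubstituted phenyl group or a nitrile in place of that methoxy group would address.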